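Swapping a Hydroxy Group for a Methoxy Group

The compounds below may be only part of what the source reports. "The series", "measured", "known", "first", "only" and "open" are said of these compounds alone.

In a physicochemical assay for lipophilicity, using the shake flask method, measured as octanol-water partition, at pH 7.4 (a higher number here means a more lipophilic compound, a lower number a more polar compound), compound 1 (`C[C@]1(C(=O)O)CSC(c2ccc(O)cc2O)=N1`) gives -1.05 and compound 2 (`COCCOCCOCCOCCOc1ccc(C2=N[C@@](C)(C(=O)O)CS2)c(O)c1`) gives -1.23 on the same scale. Among the compounds with values here, these two numbers lie within the usual scatter of each other, so compound 1 stands level with the only other measured compound. Compound 3 (`COc1ccc(C2=N[C@@](C)(C(=O)O)CS2)c(O)c1`) has not yet been measured. It differs from compound 1 in one place: methyl in place of hydrogen on an oxygen on an aromatic ring. In words, this is methyl in place of hydrogen on an oxygen on an aromatic ring, or hydroxy to methoxy. Within the data shown here, no measured pair of compounds shows this change, so the expectation here is a judgement and not a reading from the data. In this assay a modest upward move is expected, an estimated a number 0.35 log units higher from compound 1 to compound 3 (beyond the scatter) that lies only slightly beyond the scatter. For compound 3 the expected value is -0.7 and the estimated range runs from -1 to -0.35 in this measurement.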

Compound 3, partition coefficient: -0.7
Compound 3: the middle estimate sits on the measured number at the digits printed; the range from low to high includes it.
By their numbers in this assay, from the lowest: compounds 2 and 1 (each within the scatter of the next); then compound 3.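

In this assay, within the data shown here, the change from hydroxy to methoxy gives a number 0.35 log units higher from compound 1 to compound 3 (beyond the scatter) and so provides the first reading from a pair of compounds that differ in one place. At this oxygen on an aromatic ring, a single methyl in place of hydrogen is enough to carry the number past the usual scatter, although the step remains modest. Nothing measured here explains why the number moves.

A single pair cannot show whether the number would keep rising, hold steady or fall with other groups on this oxygen, such as ethyl, a chain ending in an amine or a chain ending in a carboxylic acid. It also leaves open whether the same methyl on the remaining hydroxy group of the ring would give a step of similar size.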